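The compounds below may be only part of what the source reports. "The series", "measured", "known", "first", "only" and "open" are said of these compounds alone.

Measured compounds:
Compound 1 `COc1cccc(/C=C/C(=O)c2c(OC)cc(OC)cc2OC)c1` gives 8900 nM in a functional assay on Huh-7 cells (Homo sapiens) for cytotoxicity, with a stated time of 48 h; a lower number here means a stronger inhibitor, a higher number a weaker inhibitor.
Compound 2 `COc1cc(OC)c(C(=O)/C=C/c2ccc(Br)cc2)c(OC)c1` gives 13900 nM in this assay.

Going by the values given here, compound 2 carries the higher of the two numbers, but its only neighbour is compound 1, and the step of a 1.6-fold higher number from compound 1 to compound 2 (0.19 log units; within the scatter) lies within the scatter, so the two compounds cannot be ordered on these data.

Compound 3 `COc1cc(OC)c(C(=O)/C=C/c2ccccc2OC)c(OC)c1` has not yet been measured in this assay. It differs from compound 2 in one place: 2-methoxyphenyl in place of 4-bromophenyl on a double-bonded chain carbon bound to a double-bonded chain carbon. Among the compounds with values here, the single measured step that bears on this change is the one in which 4-bromophenyl took the place of 3-methoxyphenyl, a 1.6-fold higher number from compound 1 to compound 2 (0.19 log units; within the scatter), a movement too small to be trusted. Compound 3 reverses that exchange, restoring a methoxyphenyl group, though now 2-methoxyphenyl, so the shared core is paired once more with a methoxy-bearing ring. Within the data shown here, no measured step shows what moving the methoxy group within the ring does. Compound 3 is therefore expected to sit close to compound 2, with at most a modest move toward a lower number, a 1.4-fold lower number from compound 2 to compound 3 (0.14 log units; within the scatter), and its estimated value is 10000 nM, within a range from 4000 nM to 25000 nM.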

Compound 3, half-maximal inhibitory concentration: 9800 nM
For compound 3 the middle estimate is 1.0-fold (0.01 log units) above the measured one; the measured number falls inside the stated range.
By their numbers in this assay, from the lowest: compounds 1, 3 and 2 (each within the scatter of the next).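

With compound 3, the double-bonded chain carbon bound to a double-bonded chain carbon now carries three different substituted phenyl groups on the shared core, and in this assay all three compounds lie within the scatter of one another. Going by these compounds alone, replacing 4-bromophenyl with 2-methoxyphenyl gives a 1.4-fold lower number from compound 2 to compound 3 (0.15 log units; within the scatter) and thus does not separate the two groups, while the first direct comparison of two methoxyphenyl groups, 2-methoxyphenyl in place of 3-methoxyphenyl, gives a 1.1-fold higher number from compound 1 to compound 3 (0.04 log units; within the scatter) and shows no readable difference between them either. Nothing available here bears on the cause of these small steps at this position.

As far as these compounds go, what a phenyl ring bearing an amine or a carboxylic acid would do at this position remains open, and so does whether any group placed there can produce a step beyond the scatter. From the compounds shown here alone, it is also open whether the exchanges seen here would remain as small on a core with something other than the three methoxy groups that all these compounds share.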